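A few compounds are considered here, and "the series" means these few. Any claim that something is new, unique, unknown or untested is made for them only; others in the source may bear on it.

Three compounds sharing one core were examined in an ADME assay on cells (Macrophage, Homo sapiens) for cytotoxicity, read by MTT assay, with a stated time of 24 h; on this read-out lower numbers stand for higher toxicity in this test and higher numbers for lower toxicity in this test. Compound 1 `COc1ccc(/C=C/c2ncc([N+](=O)[O-])n2CC(C)O)cc1` gives 560 nM in this assay. Compound 2 `CC(O)Cn1c([N+](=O)[O-])cnc1/C=C/c1ccc(Br)cc1` gives 550 nM in this assay, the second highest of the three numbers, with compound 1 nearest to it and compound 3 furthest. Compound 3 `CC(O)Cn1c([N+](=O)[O-])cnc1/C=C/c1cccc(Cl)c1` gives 520 nM in this assay. The change of bromo in place of methoxy on an aromatic carbon gives a 1.0-fold lower number from compound 1 to compound 2 (0.01 log units; within the scatter), and the change of 3-chlorophenyl in place of 4-bromophenyl on the double-bonded chain carbon gives a 1.1-fold lower number from compound 2 to compound 3 (0.02 log units; within the scatter); neither step leaves the scatter.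

Compound 4 `CC(O)Cn1c([N+](=O)[O-])cnc1/C=C/c1ccc([N+](=O)[O-])cc1` differs from compound 2 by nitro in place of bromo on an aromatic carbon. The two steps that bear on it, both changes at the aryl end of the chain, were flat, so no step beyond the scatter is expected in this assay for compound 4. The expected step is no change at the digits printed from compound 2 to compound 4 (within the scatter). Compound 4 is therefore estimated at 550 nM, in a range from 300 nM to 1000 nM.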

Compound 4, half-maximal cytotoxic concentration: 410 nM
The estimate for compound 4 lay 1.3-fold (0.13 log units) above the measured number; low and high end bracket the measured number.
By their numbers in this assay, from the lowest: compounds 4, 3, 2 and 1 (each within the scatter of the next).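

In this assay, nitro, with 3 heavy atoms and 2 hydrogen-bond acceptors where bromo has 1 heavy atom and no acceptor, gives a 1.3-fold lower number from compound 2 to compound 4 (0.13 log units; within the scatter), and in place of methoxy it gives a 1.4-fold lower number from compound 1 to compound 4 (0.14 log units; within the scatter). Going by these compounds alone, the aromatic carbon para to a large group thus takes a third kind of substituent, one carrying a double bond outside aromatic rings, and neither step leaves the scatter, so the flat picture from the earlier compounds now extends to nitro. Nothing available here accounts for this flatness.

On these data alone, whether an amine or a carboxylic acid on this same aromatic carbon would give a step beyond the scatter remains open. So does whether a longer chain on the shared core would move the number at all.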